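A few compounds are considered here, and "the series" means these few. Any claim that something is new, unique, unknown or untested is made for them only; others in the source may bear on it.

Compound 1 `COc1ccc(-c2coc3cc(OCCCSC(=S)N4CCCC4)ccc3c2=O)cc1` stands lowest of the two numbers in a functional assay on MGC-803 cells (Homo sapiens) for inhibition, read by MTT assay, with a stated time of 48 h (a higher number here means a weaker inhibitor, a lower number a stronger inhibitor), where compound 1 gives 40000 nM; compound 2 `CCN1CCN(C(=S)SCCCOc2ccc3c(=O)c(-c4ccc(OC)cc4)coc3c2)CC1` gives 54000 nM, with a 1.4-fold higher number from compound 1 to compound 2 (0.13 log units; within the scatter). Compound 3 `COc1ccc(-c2coc3cc(OCCBr)ccc3c2=O)cc1` differs from compound 1 by one bromine atom in place of a group of 9 heavy atoms (6 carbon, 1 nitrogen, 2 sulfur; one five-membered non-aromatic ring with 1 hetero atom), on a saturated chain carbon, two bonds along the chain from an oxygen on an aromatic ring. For the measured compounds named here, no measured step covers this change: the one known step altered only the amine part of that group and stayed within the scatter, so it gives little guidance. For compound 3 a step toward a weaker inhibitor is nonetheless expected, about a 2.0-fold higher number from compound 1 to compound 3 (0.30 log units; within the scatter). Compound 3 is therefore estimated at 80000 nM, between 30000 nM and 200000 nM.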

Compound 3, half-maximal inhibitory concentration: > 100000 nM
Compound 3: no number, only a limit; the forecaster's own chance of this, stated with the estimate: 30%; at least 1.2-fold (0.09 log units) between middle value and limit.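

In this assay compound 3 gives > 100000 nM, which is a limit of the assay and not a number. Putting bromo in place of the whole group on the saturated chain carbon gives an at least 2.5-fold higher number from compound 1 to compound 3 (0.39 log units; beyond the scatter), so a change at this position moves beyond the scatter, which the amine swap alone did not. The reading is bounded on one side only: the limit of > 100000 nM in this assay, at which 1 of the 3 values shown sits.

From the compounds shown here alone, it remains open whether a pyrrolidin-1-yl amine placed directly on the chain, without the sulfur and thiocarbonyl, would keep the number of compound 1. Going by these compounds, a longer chain ending in bromo also remains open.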